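A new group on the carbonyl of compound 3

The compounds below may be only part of what the source reports. "The series", "measured", "known", "first", "only" and "open" are said of these compounds alone.

Three compounds were measured in an ADME assay on MT4 cells (Homo sapiens) for cytotoxicity, read by MTT assay (a lower number here means that less compound is tolerated, a higher number that more compound is tolerated), with these results

Compound 1 `Cc1ccc(C(=O)N(C(=S)OCCN2C(=O)c3ccccc3C2=O)c2ccc(Cl)cc2)cc1` gives > 100000 nM as a limit of the assay
Compound 2 `O=C1c2ccccc2C(=O)N1CCOC(=S)N(C(=O)c1cccnc1Cl)c1ccc(Br)cc1` gives > 100000 nM as a limit of the assay
Compound 3 `Cc1ccc(C(=O)N(C(=S)OCCN2C(=O)c3ccccc3C2=O)c2ccc(C)cc2)cc1` gives 83000 nM as a number

Within the data shown here, compound 3 holds the only number among the three. Compound 1 and compound 2 stand at the limit of > 100000 nM in this assay, at which 2 of the 3 values shown sit, and so give no number.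

Compound 4 `Cc1ccc(N(C(=O)c2cccc(Cl)c2Cl)C(=S)OCCN2C(=O)c3ccccc3C2=O)cc1` differs from compound 3 as follows 2,3-dichlorophenyl in place of 4-methylphenyl on a carbonyl carbon and the change reads 2,3-dichlorophenyl in place of 4-methylphenyl on a carbonyl carbon. Among the measured compounds shown here, no measured step changes that group on its own. For the measured compounds named here, the one step available is an at least 1.2-fold lower number from compound 1 to compound 3 (0.08 log units; that floor lies within the scatter) and it concerns methyl in place of chloro on an aromatic carbon, a different change whose floor lies within the scatter. Compound 3 at 83000 nM therefore remains the only anchor, and no step beyond the scatter is expected in this assay in either direction. Compound 4 could also return a limit rather than a number. The estimated change is a 1.1-fold lower number from compound 3 to compound 4 (0.04 log units; within the scatter) and it is expected to stay within the scatter. For compound 4 the expected value is 75000 nM with 30000 nM to 100000 nM as the estimated range.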

Compound 4, half-maximal cytotoxic concentration: 35000 nM
Estimate against measurement, compound 4: 2.1-fold (0.33 log units) above, and the stated range covers the measured number.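

In this assay, among these compounds, the group on the carbonyl carbon gives the first step that clearly moves the number: a 2.4-fold lower number from compound 3 to compound 4 (0.38 log units; beyond the scatter). The only earlier step, an at least 1.2-fold lower number from compound 1 to compound 3 (0.08 log units; that floor lies within the scatter), concerned methyl in place of chloro on an aromatic carbon, and its floor stayed within the scatter, so this position is the first shown to matter in this assay, if only modestly. The change keeps a six-membered aromatic ring of carbon only with no net charge, so the lower number comes with a swap of the groups on that ring, although this single step cannot separate the loss of the methyl from the entry of the chlorines.

As far as these compounds go, what a single chlorine at either of the positions in 2,3-dichlorophenyl would do on its own remains open, as does the effect of an amine or a carboxylic acid on that ring in place of the chlorines. How far the trend carries across the rest of the series also stays unclear, since few values on this scale can be compared as numbers: the limit of > 100000 nM in this assay, at which 2 of the 4 values shown sit.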